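Replacing a Benzodioxin Arm with a Small Oxadiazole

The source may report more compounds than this note shows. Statements on the series, on what has been measured and on what is new or still open speak of the compounds shown alone.

Measured compounds:
Compound 1, `CC[C@@H](C(=O)N[C@@H](CC(=O)O)C(=O)CSCc1ccccc1)n1cccc(NC(=O)[C@H](CC(=O)O)NC(C)=O)c1=O`: 220 nM
Compound 2, `CCC(C(=O)N[C@@H](CC(=O)O)C(=O)CSCc1ccccc1)n1ccnc(NCC2COc3ccccc3O2)c1=O`: 8220 nM
Compound 3, `CCC(C(=O)N[C@@H](CC(=O)O)C(=O)CNCN1CCCCC1)n1cc(C(C)(C)C)nc(NCc2nonc2C)c1=O`: > 10000 nM

All three were tested in an assay for inhibition of Caspase-8 (Homo sapiens); on this read-out higher numbers stand for weaker inhibition and lower numbers for stronger inhibition. Compound 1 is the stronger of the two compounds that gave a number, with 220 nM. Compound 2 stands at the highest of the two numbers shown, 8220 nM, a gap to compound 1 that lies well beyond the usual scatter. Compound 3 gave no number at all, only a limit of this assay, > 10000 nM, as described in the limit of > 10000 nM in this assay, at which 1 of the 3 values shown sits.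

Compound 4, `CCC(C(=O)N[C@@H](CC(=O)O)C(=O)CSCc1ccccc1)n1ccnc(NCc2nc(C)no2)c1=O`, has not yet been measured. It keeps the whole framework of compound 2 and differs in one spot: 3-methyl-1,2,4-oxadiazol-5-yl in place of 2,3-dihydro-1,4-benzodioxin-2-yl on a saturated chain carbon bound to a nitrogen on an aromatic ring. Within the data shown here, nothing among the measured compounds isolates this single change, since compound 3 differs from compound 2 in several places at once.

Without a comparable measured step, the expected step of a 1.2-fold higher number from compound 2 to compound 4 (0.06 log units; within the scatter) is small, with a slight lean toward weaker inhibition, given that compound 2 already sits at 8220 nM. For compound 4 the estimate is 9500 nM, within a range from 3000 nM to 30000 nM.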

Compound 4, half-maximal inhibitory concentration: 6420 nM
The estimate for compound 4 lay 1.5-fold (0.17 log units) above the measured number, and the stated range covers the measured number.
By their numbers in this assay, from the lowest: compound 1; then compounds 4 and 2 (each within the scatter of the next). At a limit, above all of these: compound 3.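

Among these compounds, putting 3-methyl-1,2,4-oxadiazol-5-yl in place of 2,3-dihydro-1,4-benzodioxin-2-yl gives the only comparison here that isolates a single place, and in this assay it reads a 1.3-fold lower number from compound 2 to compound 4 (0.11 log units; within the scatter). At this saturated chain carbon, then, an arm of 6 heavy atoms with one five-membered aromatic ring cannot be told apart from an arm of 10 heavy atoms with two six-membered rings, so these two arms give no handle on inhibition. Compound 3 gives only a limit, not a number, so it adds no step to this comparison: the limit of > 10000 nM in this assay, at which 1 of the 4 values shown sits.

As far as these compounds go, whether an arm ending in a primary amine or a carboxylic acid at this place would shift the number remains open. The compounds shown also cannot tell whether this swap would read the same on another core, such as that of compound 1.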